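Urea aryl variation on a shared core

The compounds below may be only part of what the source reports. "The series", "measured", "known", "first", "only" and "open" are said of these compounds alone.

Working notes on a short urea series built on one core. Compound 1 `O=C(Nc1ccc(Cl)cc1)Nc1ccc(Nc2ncnc3c2OCCN3)cc1` carries a 4-chlorophenyl on an amide-type nitrogen; in an assay on isolated protein for inhibition of proto-oncogene tyrosine-protein kinase receptor Ret variant V804L (Homo sapiens), read by 33P incorporation, with stated times of 15 min and 40 min (a higher number here means a weaker inhibitor, a lower number a stronger inhibitor), compound 1 gives only a limit, > 10000 nM. Compound 2 `COc1cccc(NC(=O)Nc2ccc(Nc3ncnc4c3OCCN4)cc2)c1` bears a 3-methoxyphenyl there and in this assay compound 2 likewise stops at a limit, > 10000 nM. Going by the values given here, compound 3 `Cc1ccc(F)c(NC(=O)Nc2ccc(Nc3ncnc4c3OCCN4)cc2)c1`, with a 2-fluoro-5-methylphenyl, is the only member with a number: in this assay compound 3 gives 7000 nM. The steps read an at least 1.4-fold lower number from compound 1 to compound 3 (0.15 log units; that floor lies within the scatter) and an at least 1.4-fold lower number from compound 2 to compound 3 (0.15 log units; that floor lies within the scatter), both floors set by the limit of > 10000 nM in this assay, at which 2 of the 3 values shown sit, so compound 3 is not separable from the others beyond the scatter.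

Compound 4 `Cc1cc(C)cc(NC(=O)Nc2ccc(Nc3ncnc4c3OCCN4)cc2)c1` is now to be measured. The change is 3,5-dimethylphenyl in place of 2-fluoro-5-methylphenyl on an amide-type nitrogen. Among the compounds with values here, no measured step covers a swap of one aryl for another once the fluorine is removed; the two known steps only lead into compound 3. The expected step is therefore none beyond the scatter, no change at the digits printed from compound 3 to compound 4 (within the scatter). Compound 4 is expected to give 7000 nM, with a range from 2500 nM to 20000 nM, and a limit remains a real possibility.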

Compound 4, half-maximal inhibitory concentration: 3770 nM
Estimate against measurement, compound 4: 1.9-fold (0.27 log units) above, within the range that was stated.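

In this assay, going by these compounds alone, the steps of an at least 2.6-fold lower number from compound 2 to compound 4 (0.42 log units; beyond the scatter) and an at least 2.6-fold lower number from compound 1 to compound 4 (0.42 log units; beyond the scatter) are the first to clear the scatter, so at this position on an amide-type nitrogen 3,5-dimethylphenyl separates from both 3-methoxyphenyl and 4-chlorophenyl. Both steps give only floors, not sizes, because one end of each is a limit: the limit of > 10000 nM in this assay, at which 2 of the 4 values shown sit. The step of a 1.9-fold lower number from compound 3 to compound 4 (0.27 log units; within the scatter) does not separate 3,5-dimethylphenyl from 2-fluoro-5-methylphenyl, so replacing the fluorine with a methyl group shows no readable change here.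

On these data alone, the true sizes of the two floored steps remain open. Also open, as far as these compounds go, is how this position responds to a trifluoromethyl or dimethylamino group on the phenyl ring, or to a cyclohexyl group or longer alkyl chain in place of the aryl group.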